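Moving from a short amino chain to a diethylamino chain

The compounds below may be only part of what the source reports. "The series", "measured", "known", "first", "only" and "open" are said of these compounds alone.

- compound 1 `NCCCCN(C[C@H]1Cc2cccnc2CN1)[C@H]1CCCc2cccnc21` (6 nm/s)
- compound 2 `NCCCCN(C[C@@H]1Cc2cccnc2CN1)[C@H]1CCCc2cccnc21` (77 nm/s)
- compound 3 `NC/C=C\CN(C[C@H]1Cc2ncccc2CN1)[C@H]1CCCc2cccnc21` (68 nm/s)

These values all come from an ADME assay for permeability, using PAMPA, with a stated time of 4 h, at pH 7.4; on this read-out lower numbers stand for lower permeability and higher numbers for higher permeability (the only read-out here). Compound 3 (68 nm/s) lies within the usual scatter of compound 2 (77 nm/s) and clearly above compound 1 (6 nm/s).

The open question is compound 4 `CCN(CC)CCCCN(C[C@H]1Cc2ncccc2CN1)[C@H]1CCCc2cccnc21` (not yet measured). It differs from compound 3 in one chain: 3-(diethylamino)propyl in place of 3-aminoprop-1-en-1-yl on a saturated chain carbon bound to an amine nitrogen (cut one bond further out, 4-aminobut-2-en-1-yl gives way to 4-(diethylamino)butyl).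

For the measured compounds named here, only one measured step is available, and it bears on this change only loosely: a 13-fold higher number from compound 1 to compound 2 (1.11 log units; beyond the scatter) (a large step). It comes with the fact that compounds 1 and 2 differ only in the configuration as drawn (so no chain changed in that pair). It shows that numbers in this small set can move a long way, but it gives neither a size nor a direction for a chain swap. With no measured chain change to go on, the value of compound 3 remains the best anchor, and no step beyond the scatter is expected.

The estimated step is a 1.3-fold higher number from compound 3 to compound 4 (0.12 log units; within the scatter) (a central guess, held loosely). For compound 4 the expected value is 90 nm/s (estimated range 20 nm/s to 350 nm/s).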

Compound 4, apparent permeability: 240 nm/s
Beside the measured number, compound 4's estimate is 2.7-fold (0.43 log units) below it; the range from low to high includes it.
By their numbers in this assay, from the lowest: compound 1; then compounds 3 and 2 (each within the scatter of the next); then compound 4.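

In this assay, for the compounds shown here, this is the first measured change of a chain in the set, and it goes beyond the usual scatter: a 3.5-fold higher number from compound 3 to compound 4 (0.55 log units; beyond the scatter). Going by these compounds alone, at this place, on a saturated chain carbon bound to an amine nitrogen, 3-(diethylamino)propyl and 3-aminoprop-1-en-1-yl are therefore not interchangeable, whereas the one earlier step, a 13-fold higher number from compound 1 to compound 2 (1.11 log units; beyond the scatter), involved configuration alone and said nothing about a chain. The entering chain has 8 heavy atoms against 4, 0 hydrogen-bond donors against 1 and no double bond outside aromatic rings, but nothing measured here explains the higher number or singles out one of these differences.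

Several differences arrive together in this one pair, so it remains open whether the higher number goes with the diethylamino end, with the saturated chain or with both. From the compounds shown here alone, it is also open how a dimethylamino group or a piperidine ring at the chain end, a carboxylic acid, or a longer chain would read in this assay at this place.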